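A 5-cyanopyridin-2-yl amide after compound 3

The compounds below may be only part of what the source reports. "The series", "measured", "known", "first", "only" and "open" are said of these compounds alone.

In an ADME assay on microsomes from liver (Rattus norvegicus, strain Crj;CD(SD)) for metabolic stability, read by LC-MS, using NADPH, with a stated time of 30 min, tested at 0.1 uM (on this read-out lower numbers stand for a less stable compound and higher numbers for a more stable compound), compound 1 `C[C@@]1(c2cc(NC(=O)c3cnc(OCF)cn3)ccc2F)C=C(CF)OC(N)=N1` gives 52%, compound 2 `C[C@@]1(c2cc(NC(=O)c3coc(C(F)F)n3)ccc2F)C=C(CF)OC(N)=N1` gives 57% and compound 3 `C[C@@]1(c2cc(NC(=O)c3cnc(C(F)F)cn3)ccc2F)C=C(CF)OC(N)=N1` gives 44%. Two steps place this last value: a number 8 percentage points lower from compound 1 to compound 3 (within the scatter), and a number 13 percentage points lower from compound 2 to compound 3 (beyond the scatter). Compound 4 `C[C@@]1(c2cc(NC(=O)c3ccc(C#N)cn3)ccc2F)C=C(CF)OC(N)=N1` carries 5-cyanopyridin-2-yl in place of 5-(difluoromethyl)pyrazin-2-yl on a carbonyl carbon. Among the measured compounds shown here, no measured compound holds this group, so the closest guides are the other exchanges at that carbonyl carbon, a number 5 percentage points higher from compound 1 to compound 2 (within the scatter) and a number 13 percentage points lower from compound 2 to compound 3 (beyond the scatter). They differ in size and direction, so no step beyond the scatter is expected, and the estimated step is a number 6 percentage points higher from compound 3 to compound 4 (within the scatter). Compound 4 is expected at 50%, within an estimated range of 35% to 65%.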

Compound 4, percent of the compound remaining: 55%
Beside the measured number, compound 4's estimate is 5 percentage points below it; low and high end bracket the measured number.
By their numbers in this assay, from the lowest: compounds 3, 1, 4 and 2 (each within the scatter of the next, the first and the last beyond it).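

In this assay, 5-cyanopyridin-2-yl in place of 5-(difluoromethyl)pyrazin-2-yl on a carbonyl carbon gives a number 11 percentage points higher from compound 3 to compound 4 (beyond the scatter). Against the other two groups the exchange gives a number 2 percentage points lower from compound 2 to compound 4 (within the scatter) and a number 3 percentage points higher from compound 1 to compound 4 (within the scatter), so a group without fluorine can stand at this carbonyl carbon with no step beyond the scatter from compound 1 or compound 2. Nothing available accounts for the step from compound 3. The compounds shown leave open whether the nitrile or the pyridine ring carries that step, which a pyrazine ring bearing the nitrile, or a pyridine ring bearing difluoromethyl, would separate.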